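The compounds below may be only part of what the source reports. "The series", "measured", "known", "first", "only" and "open" are said of these compounds alone.

Compound 3 `COc1ccc(/C=C\C(=O)O)c(OCc2cn(-c3cccnc3Cl)nn2)c1CC=C(C)C` gives 42200 nM in a functional assay on NCI-H322 cells (Homo sapiens) for cytotoxicity, read by MTT assay, with a stated time of 24 h (on this read-out lower numbers stand for stronger inhibition and higher numbers for weaker inhibition), the highest of the three numbers shown, although its steps to the other two compounds stay within the scatter. Compound 1 `COc1ccccc1-n1cc(COc2c(/C=C\C(=O)O)ccc(OC)c2CC=C(C)C)nn1` gives 41500 nM in this assay, and compound 2 `COc1ccc(/C=C\C(=O)O)c(OCc2cn(-c3cccc(C#N)c3)nn2)c1CC=C(C)C` gives 26500 nM in this assay. Compound 4 `COc1ccc(/C=C\C(=O)O)c(OCc2cn(-c3cccc([N+](=O)[O-])c3)nn2)c1CC=C(C)C` differs from compound 3 by 3-nitrophenyl in place of 2-chloropyridin-3-yl on an aromatic nitrogen. The measured steps that bear on this change all exchange the aryl group on the same aromatic nitrogen: a 1.6-fold lower number from compound 1 to compound 2 (0.19 log units; within the scatter), a 1.0-fold higher number from compound 1 to compound 3 (0.01 log units; within the scatter) and a 1.6-fold higher number from compound 2 to compound 3 (0.20 log units; within the scatter). Since none of these moved beyond the scatter, no step beyond the scatter is expected in this assay for compound 4 either. Compound 4 is therefore estimated at 35000 nM, with a range from 15000 nM to 85000 nM, which corresponds to an expected step of a 1.2-fold lower number from compound 3 to compound 4 (0.08 log units; within the scatter).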

Compound 4, half-maximal inhibitory concentration: 43200 nM
Estimate against measurement, compound 4: 1.2-fold (0.09 log units) below; the range from low to high includes it.
By their numbers in this assay, from the lowest: compounds 2, 1, 3 and 4 (each within the scatter of the next).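

In this assay the 3-nitrophenyl group adds one more aryl exchange on this aromatic nitrogen that stays within the scatter, with a 1.0-fold higher number from compound 3 to compound 4 (0.01 log units; within the scatter) in place of 2-chloropyridin-3-yl and a 1.0-fold higher number from compound 1 to compound 4 (0.02 log units; within the scatter) in place of 2-methoxyphenyl. Nitro in place of cyano on an aromatic carbon, a change within the aryl group itself, gives a 1.6-fold higher number from compound 2 to compound 4 (0.21 log units; within the scatter) and so stays within the scatter as well. On these data alone, whether an amine on the phenyl ring, or a plain alkyl chain on that nitrogen in place of the aryl group, would move the number stays open. No measurement shown here explains why these exchanges stay within the scatter.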